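The source may report more compounds than this note shows. Statements on the series, on what has been measured and on what is new or still open speak of the compounds shown alone.

Measured compounds:
- compound 1, `C[C@]1(CN2CCc3nc(C4CC4)ccc3C2)Cn2cc([N+](=O)[O-])nc2O1`, in an ADME assay on Vero cells (Chlorocebus sabaeus) for cytotoxicity, read by MTT assay, with a stated time of 72 h; on this read-out lower numbers stand for higher toxicity in this test and higher numbers for lower toxicity in this test: "not determined" (no result reported)
- compound 2, `C[C@]1(CN2CCc3nc(C4CCOCC4)ccc3C2)Cn2cc([N+](=O)[O-])nc2O1`, in this assay: "not determined" (no result reported)
- compound 3, `C[C@]1(CN2CCc3nc(-c4ccc(C(F)(F)F)cc4)ccc3C2)Cn2cc([N+](=O)[O-])nc2O1`, in this assay: > 32 ug/mL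

For the measured compounds named here, compound 3 stands on the only value with a number attached in this set. In this assay compound 3 gives > 32 ug/mL, which is a limit of the test and not a measured number; it sits at the limit of > 32 ug/mL in this assay, at which 1 of the 3 values shown sits. Going by the values given here, compounds 1 and 2 carry no result, so no step between measured compounds can be computed and compound 3 has no measured neighbour against which to place it.

Compound 4, `C[C@]1(CN2CCc3nc(-c4ccc(F)c(F)c4)ccc3C2)Cn2cc([N+](=O)[O-])nc2O1`, is the compound still to be measured. It differs from compound 3 in one place: 3,4-difluorophenyl in place of 4-(trifluoromethyl)phenyl on an aromatic carbon. Among the compounds with values here, with no measured step available, the expectation for the change is a step from compound 3 to compound 4 of no size beyond the usual scatter, a step that the limit leaves unreadable from compound 3 to compound 4, and this is an estimate only.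

For compound 4 the estimated result in this assay is 40 ug/mL, with a range from 16 ug/mL to 100 ug/mL, and a further limit rather than a number is expected to be the likelier outcome.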

Compound 4, half-maximal cytotoxic concentration: > 32 ug/mL
Compound 4 gave a limit, no number (the forecaster's own chance of this, stated with the estimate: 70%); the middle value does not contradict the limit.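

No step can be read between compound 3 and compound 4 in this assay, because both results are limits and not numbers: the limit of > 32 ug/mL in this assay, at which 2 of the 4 values shown sit.

The compounds shown leave open whether 3,4-difluorophenyl in place of 4-(trifluoromethyl)phenyl changes the half-maximal cytotoxic concentration at all, and where either compound's true value lies.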